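The source may report more compounds than this note shows. Statements on the series, on what has been measured and on what is new or still open speak of the compounds shown alone.

Working notes on the series. In a functional assay on OCI-Ly3 cells (Homo sapiens) for antiproliferative activity (on this read-out lower numbers stand for an effect already at smaller amounts and higher numbers for an effect only at larger amounts of compound), compound 1 `CC(C)c1c(NC(=O)Nc2cnc(-n3nccn3)c(Cl)c2)cnc2ccccc12` gives 2420 nM and compound 2 `COC(C)c1c(NC(=O)Nc2cnc(-n3nccn3)c(Cl)c2)cnc2sc(C)nc12` gives 730 nM as the lower of the two numbers, a gap beyond the usual scatter. Within the data shown here, with only these two values measured, compound 2 is the best-placed compound so far, and no pattern can be drawn from the pair.

The next compound is compound 3 `CCOC(C)c1c(NC(=O)Nc2cnc(-n3nccn3)c(Cl)c2)cnc2sc(C)nc12`, reached from compound 2 by methyl in place of hydrogen on a saturated chain carbon bound to an oxygen on a saturated carbon in one place: methyl in place of hydrogen on a saturated chain carbon bound to an oxygen on a saturated carbon, so 1-methoxyethyl to 1-ethoxyethyl. Among the measured compounds shown here, no measured pair shows this change, so the expectation rests on its small size alone. In this assay the expected 1.0-fold lower number from compound 2 to compound 3 (0.02 log units; within the scatter) stays within the scatter, with no firm direction. For compound 3 the estimated value is 700 nM with an expected range of 300 nM to 1600 nM as the working span.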

Compound 3, half-maximal effective concentration: 360 nM
Compound 3: the middle estimate sits 1.9-fold (0.29 log units) above what was measured; the range from low to high includes it.
By their numbers in this assay, from the lowest: compound 3; then compound 2; then compound 1.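

In this assay, among these compounds, the change from 1-methoxyethyl to 1-ethoxyethyl gives a 2.0-fold lower number from compound 2 to compound 3 (0.31 log units; beyond the scatter) as the first step that differs in one place. The position on the saturated chain carbon bound to an oxygen is therefore not indifferent to the size of this chain: a single added methyl gives a modest shift, beyond the scatter, towards an effect at smaller amounts. Nothing available explains this shift.

Going by these compounds, whether the number keeps falling with a longer chain such as propoxy, or with a branched one such as isopropoxy, remains open, as does the outcome of replacing the ether oxygen's chain with a hydroxyl or an amine. This single pair also leaves open whether the same change would give a similar step on another core.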